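A few compounds are considered here, and "the series" means these few. Any claim that something is new, unique, unknown or untested is made for them only; others in the source may bear on it.

Measured in a functional assay on A549 cells (Homo sapiens) for cytotoxicity, read by MTT assay, with a stated time of 48 h; on this read-out higher numbers stand for weaker inhibition and lower numbers for stronger inhibition:
compound 1, `Cc1ccc(S(=O)(=O)/N=C(/CCNC2=CC(=O)c3ccccc3C2=O)Nc2ccc(F)cc2)cc1`, gives 9330 nM
compound 2, `Cc1ccc(S(=O)(=O)/N=C(/CCNC2=CC(=O)c3ccccc3C2=O)Nc2ccccc2[N+](=O)[O-])cc1`, gives 5010 nM
compound 3, `Cc1ccc(S(=O)(=O)/N=C(/CCNC2=CC(=O)c3ccccc3C2=O)Nc2ccccc2I)cc1`, gives 24700 nM

Compound 3 stands at the highest number of the three. Its nearest neighbour is compound 1: the step of a 2.6-fold higher number from compound 1 to compound 3 (0.42 log units; beyond the scatter) is modest and beyond the scatter. Furthest away is compound 2: a 4.9-fold higher number from compound 2 to compound 3 (0.69 log units; beyond the scatter) is also modest, yet clearly beyond the scatter. Between compound 1 and compound 2 the step of a 1.9-fold lower number from compound 1 to compound 2 (0.27 log units; within the scatter) lies within the scatter.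

Compound 4, `Cc1ccc(S(=O)(=O)/N=C(/CCNC2=CC(=O)c3ccccc3C2=O)Nc2cccc(C(F)(F)F)c2)cc1`, has not yet been measured. It differs from compound 3 in one place: 3-(trifluoromethyl)phenyl in place of 2-iodophenyl on an amine nitrogen. Going by the values given here, no measured step exchanges exactly these two groups. Among the compounds with values here, the steps that bear on it are the two that put 2-iodophenyl into the same place, a 2.6-fold higher number from compound 1 to compound 3 (0.42 log units; beyond the scatter) and a 4.9-fold higher number from compound 2 to compound 3 (0.69 log units; beyond the scatter), each raising the number by a modest amount. In compound 4 the 2-iodophenyl leaves again, though what enters, 3-(trifluoromethyl)phenyl, resembles neither 4-fluorophenyl nor 2-nitrophenyl. The three measured aryl groups span only a small range, with 2-iodophenyl at the top. For compound 4 a modest step to a lower number is therefore expected in this assay, a 2.5-fold lower number from compound 3 to compound 4 (0.39 log units; beyond the scatter). Compound 4 is estimated at 10000 nM, with a range from 4000 nM to 30000 nM.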

Compound 4, half-maximal inhibitory concentration: 78500 nM
Compound 4: middle estimate off by 7.9-fold (0.89 log units), on the low side, and the stated range ends below it.
By their numbers in this assay, from the lowest: compounds 2 and 1 (each within the scatter of the next); then compound 3; then compound 4.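

In this assay the aryl group on the amine nitrogen turns out to have a wider reach than the first three compounds suggested, for 3-(trifluoromethyl)phenyl gives the highest number of the series, with a 3.2-fold higher number from compound 3 to compound 4 (0.50 log units; beyond the scatter) above the former top of the range. Going by these compounds alone, the gaps to the other two aryl groups are wider still, an 8.4-fold higher number from compound 1 to compound 4 (0.92 log units; beyond the scatter) and a 16-fold higher number from compound 2 to compound 4 (1.20 log units; beyond the scatter), and the second of these is the first large step seen at this place, with the rest of the structure unchanged. Fluorine on the aryl group does not by itself fix the number here, since compound 1 and compound 4 both carry it and yet stand well apart, and nothing available explains the rise of compound 4.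

The compounds shown leave open how a plain phenyl, or a phenyl bearing a methoxy or an amino group, would stand at this place. They also leave open whether a saturated group such as cyclohexyl on the same nitrogen would follow the aryl groups at all.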